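Piperazinyl acetanilide series: anilide substituent and cytotoxicity

The source may report more compounds than this note shows. Statements on the series, on what has been measured and on what is new or still open speak of the compounds shown alone.

Measured compounds:
- compound 1, `Cc1ccc(NC(=O)CN2CCN(c3nnc(Cc4ccccc4)c4ccccc34)CC2)c(C)c1`: "not active" (no number reported)
- compound 2, `O=C(CN1CCN(c2nnc(Cc3ccccc3)c3ccccc23)CC1)Nc1ccc(F)c(Cl)c1`: 13300 nM
- compound 3, `Cc1ccccc1NC(=O)CN1CCN(c2nnc(Cc3ccccc3)c3ccccc23)CC1`: 113000 nM

In a functional assay on HT-29 cells (Homo sapiens) for cytotoxicity, read by MTT assay, with a stated time of 72 h (a higher number here means a weaker inhibitor, a lower number a stronger inhibitor), compound 3 gives the highest of the two numbers available. Its nearest neighbour is compound 2, and the step of an 8.5-fold higher number from compound 2 to compound 3 (0.93 log units; beyond the scatter) shows that trading 3-chloro-4-fluorophenyl for 2-methylphenyl on the amide-type nitrogen weakened the inhibitor. Among the measured compounds shown here, compound 1 carries a further methylated phenyl and is reported as not active in this assay, with no number given, so it adds no step to compare.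

Compound 4, `O=C(CN1CCN(c2nnc(Cc3ccccc3)c3ccccc23)CC1)Nc1cc(C(F)(F)F)ccc1Cl`, has not been measured. The change from compound 3 is 2-chloro-5-(trifluoromethyl)phenyl in place of 2-methylphenyl on an amide-type nitrogen.

For the measured compounds named here, the only step that bears on this change is an 8.5-fold higher number from compound 2 to compound 3 (0.93 log units; beyond the scatter), in which a halogen-bearing phenyl gave the lower number and the methylated phenyl gave the higher one. Compound 4 returns to a halogen-bearing phenyl, bearing chlorine and a trifluoromethyl group, so a step downward in the number of a size comparable to that step is expected, a 4.5-fold lower number from compound 3 to compound 4 (0.66 log units; beyond the scatter). Going by the values given here, the scatter and the single supporting step leave the range wide.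

For compound 4 the expected value in this assay is 25000 nM, with a likely range from 8000 nM to 80000 nM.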

Compound 4, half-maximal inhibitory concentration: 66800 nM
Compound 4: middle estimate off by 2.7-fold (0.43 log units), on the low side; the range from low to high includes it.
By their numbers in this assay, from the lowest: compound 2; then compounds 4 and 3 (each within the scatter of the next).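

In this assay the swap of 2-methylphenyl for 2-chloro-5-(trifluoromethyl)phenyl on the amide-type nitrogen leaves the number unresolved from that of the methylated anilide (a 1.7-fold lower number from compound 3 to compound 4 (0.23 log units; within the scatter)), so a chlorine and a trifluoromethyl group on this phenyl do not reproduce the low number of compound 2. Compound 2 stays apart from the new anilide (a 5.0-fold higher number from compound 2 to compound 4 (0.70 log units; beyond the scatter)), which shows that the earlier gap between compound 2 and compound 3 cannot be read as a general halogen effect: among the halogen-bearing anilides, compound 4 goes against such a pattern, and at this position the identity and placement of the substituents matter more than the mere presence of halogen. Nothing shown here gives a measured reason for these differences.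

The compounds shown leave open whether the low number of compound 2 comes from its chlorine, its fluorine or the two together, since these two halogen-bearing anilides differ in more than one substituent at once. They also leave open how a plain phenyl, or a phenyl carrying an amine or a carboxylic acid, would read at this position.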